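Cyano in Place of Hydrogen: Expecting Compound 3

This account rests on a few compounds, and the source may have more. Where it says the series, first, only, none or still open, it means among the compounds named here.

Compound 1 `CC(C)c1ccc(NC(=O)c2csc(Cc3c(Cl)cccc3Cl)n2)cc1` gives 370 nM in an assay on CHO cells, read by calcium flux; on this read-out higher numbers stand for weaker inhibition and lower numbers for stronger inhibition. Compound 2 `O=C(Nc1ccccc1)c1csc(Cc2c(Cl)cccc2Cl)n1` reaches only the limit of this assay, > 4000 nM.

Compound 2 therefore stands at the weaker end of what has been measured, with a limit rather than a number, as shown by the limit of > 4000 nM in this assay, at which 1 of the 2 values shown sits. Among the compounds with values here, only one step between measured compounds is known: an at least 10-fold higher number from compound 1 to compound 2 (1.03 log units; beyond the scatter), brought on by hydrogen in place of isopropyl on an aromatic carbon. Compound 3 `N#Cc1ccc(NC(=O)c2csc(Cc3c(Cl)cccc3Cl)n2)cc1` differs from compound 2 by cyano in place of hydrogen on an aromatic carbon. Within the data shown here, the measured step concerns the same place on the ring but a different entering group, so it shows only that a group at this place can matter, not how much cyano will. Because of an at least 10-fold higher number from compound 1 to compound 2 (1.03 log units; beyond the scatter) some gain is expected, but a modest one: the step from compound 2 to compound 3 is estimated as an at least 2.0-fold lower number from compound 2 to compound 3 (0.30 log units; that floor lies within the scatter). Compound 3 is estimated at 2000 nM, expected to lie between 500 nM and 8000 nM.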

Compound 3, half-maximal inhibitory concentration: 450 nM
The estimate for compound 3 lay 4.4-fold (0.65 log units) above the measured number; measured number outside the range, below it.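

In this assay, within the data shown here, a second group at this place on the ring, para to a large group, also brings back a measurable number (an at least 8.8-fold lower number from compound 2 to compound 3 (0.94 log units; beyond the scatter)), so isopropyl is not the only group that does this. Cyano and isopropyl cannot be told apart here (a 1.2-fold higher number from compound 1 to compound 3 (0.09 log units; within the scatter)), although one is a nitrile and the other a branched chain. The gain from hydrogen to cyano can be given only as a floor, because compound 2 sits at a limit of the assay: the limit of > 4000 nM in this assay, at which 1 of the 3 values shown sits.

Going by these compounds, it stays open whether the identity of the group matters much, or only that something other than hydrogen sits here; a methoxy group, an amine, a carboxylic acid or a longer chain at this place could begin to separate these readings. On these data alone, whether cyano elsewhere on this ring would serve equally well also stays open.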